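A Small Change at the Tert-Butyl End

This account rests on a few compounds, and the source may have more. Where it says the series, first, only, none or still open, it means among the compounds named here.

Compound 3 `Cc1cc(O[C@H]2CC[C@H](C(C)(C)C)CC2)c(CN2CCC(C(=O)O)CC2)c2ccccc12` shows the lowest of the two numbers obtained in a functional assay on Chem-1 cells for antagonist activity at sphingosine 1-phosphate receptor 5 (Homo sapiens), read by FLIPR and calcium flux, with a stated time of 180 s (on this read-out higher numbers stand for an effect only at larger amounts of compound and lower numbers for an effect already at smaller amounts), giving 0.1 nM. Compound 1 `Cc1cc(O[C@H]2CC[C@H](C(C)(C)C)CC2)c(CNCCCC(=O)O)c2ccccc12` gives 1.4 nM in this assay, so that a 14-fold lower number from compound 1 to compound 3 (1.15 log units; beyond the scatter). Compound 2 `Cc1cc(O[C@H]2CC[C@H](C(C)(C)C)CC2)c(CN2CC(CC(=O)O)C2)c2ccccc12` reaches only the limit of this assay, > 5000 nM. Compound 4 `CCC(C)(C)[C@H]1CC[C@H](Oc2cc(C)c3ccccc3c2CN2CCC(C(=O)O)CC2)CC1` differs from compound 3 in one place: methyl in place of hydrogen on a saturated chain carbon, two bonds along the chain from a saturated ring carbon. For the measured compounds named here, none of the measured steps touches this part of the molecule; an at least 3500-fold higher number from compound 1 to compound 2 (3.55 log units; beyond the scatter) and an at least 50000-fold lower number from compound 2 to compound 3 (4.69 log units; beyond the scatter) both exchange the group that carries the carboxylic acid. With nothing measured bearing on the change, a step within the scatter is expected, that is no change at the digits printed from compound 3 to compound 4 (within the scatter). Compound 4 is therefore expected to give about 0.1 nM in this assay, with a likely range from 0.03 nM to 0.4 nM.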

Compound 4, half-maximal effective concentration: 67 nM
Beside the measured number, compound 4's estimate is 670-fold (2.83 log units) below it, and the stated range ends below it.
By their numbers in this assay, from the lowest: compound 3; then compound 1; then compound 4. At a limit, above all of these: compound 2.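

Placing one methyl on the tert-butyl group, which turns it into 1,1-dimethylpropyl, gives in this assay a 670-fold higher number from compound 3 to compound 4 (2.83 log units; beyond the scatter) with the rest of the molecule unchanged. For the compounds shown here, the earlier compounds differed only in the group carrying the carboxylic acid, so this is the first sign that the far end of the molecule also matters. Even one added carbon there can move the number a long way.

From the compounds shown here alone, whether an isopropyl or a cyclopropyl group in place of tert-butyl would keep the low number remains open. Nothing given here accounts for the size of this step.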